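The source may hold more compounds than are shown below. What is called first, only, known or untested is meant among the compounds shown, and "the series" means these compounds.

Working notes on the series.

Two compounds have numbers in a functional assay on cells (T-cell line, Homo sapiens) for inhibition (on this read-out higher numbers stand for weaker inhibition and lower numbers for stronger inhibition), so far. Compound 1 `COc1ccc(CCCN2CCC(COC(c3ccc(Br)cc3)c3ccc(Br)cc3)CC2)cc1` gives 3200 nM in this assay. Compound 2 `Cc1ccc(CCCN2CCC(COC(c3ccccc3)c3ccccc3)CC2)cc1` gives 200 nM in this assay, which is the lowest of the two numbers; the gap to compound 1 lies beyond the usual scatter of repeated measurements, so compound 2 is the stronger inhibitor of the pair. Going by the values given here, no single-point step between the two measured compounds is available, as they differ in more than one place, so the two numbers are taken only as they stand.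

Compound 3 `c1ccc(C(OCC2CCN(CC3CCc4ccccc4C3)CC2)c2ccccc2)cc1` has not yet been measured in this assay. Against compound 2 it differs in one place: 1,2,3,4-tetrahydronaphthalen-2-yl in place of 2-(4-methylphenyl)ethyl on a saturated chain carbon bound to an amine nitrogen in a ring. The change keeps the amine nitrogen in a ring and its saturated chain carbon and exchanges the group carried on that carbon. Nothing measured in the series speaks to this exchange directly.

For compound 3 a step of a 2.0-fold higher number from compound 2 to compound 3 (0.30 log units; within the scatter) is expected in this assay, small, toward a somewhat higher number, or none beyond the scatter. The estimate for compound 3 in this assay is 400 nM, with a range from 100 nM to 2000 nM.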

Compound 3, half-maximal inhibitory concentration: 5600 nM
Compound 3: the middle estimate sits 14-fold (1.15 log units) below what was measured; the whole stated range lies below it.
By their numbers in this assay, from the lowest: compound 2; then compounds 1 and 3 (each within the scatter of the next).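

In this assay, going by these compounds alone, the group on a saturated chain carbon bound to an amine nitrogen in a ring proves to matter strongly: 1,2,3,4-tetrahydronaphthalen-2-yl in place of 2-(4-methylphenyl)ethyl gives a 28-fold higher number from compound 2 to compound 3 (1.45 log units; beyond the scatter) as the first single-place step. The exchange keeps one six-membered aromatic ring of carbon only and adds one six-membered non-aromatic ring of carbon only, while neither group carries a hydrogen-bond donor, a hydrogen-bond acceptor or a net charge, so the large loss of inhibition appears with a change confined to the carbon framework. No measurement at hand bears on the cause of this step.

Going by these compounds, whether the loss goes with the added non-aromatic ring or with the absent methyl on the aromatic ring stays open, and an unsubstituted 2-phenylethyl group or an indan-2-yl group in the same place would separate the two. Within the data shown here, the separate contributions of the bromine atoms and the methoxy group in compound 1 also remain unresolved, since no single-place step reaches that compound.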